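Aryl swap on a triazole: compound 2 to compound 4

The compounds below may be only part of what the source reports. "The series", "measured", "known", "first", "only" and "open" are said of these compounds alone.

Compound 1 `CC(C)(C)c1cn(C[C@H](O)[C@H]2OC(=O)C(OCc3ccccc3)=C2OCc2ccccc2)nn1` gives 28300 nM in a functional assay on HCT-116 cells (Homo sapiens) for antiproliferative activity, read by MTT assay, with a stated time of 72 h; on this read-out lower numbers stand for stronger inhibition and higher numbers for weaker inhibition.
Compound 3 `Cc1ccc(S(=O)(=O)NCc2cn(C[C@H](O)[C@H]3OC(=O)C(OCc4ccccc4)=C3OCc3ccccc3)nn2)cc1` gives 13100 nM in this assay.
Compound 2 `COc1ccc(-c2cn(C/C=C3\OC(=O)C(OCc4ccccc4)=C3OCc3ccccc3)nn2)cc1` reaches only the assay limit of > 100000 nM in this assay.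

Compound 2 thus stands at the limit of > 100000 nM in this assay, at which 1 of the 3 values shown sits, and offers no number to build on. Compound 4 `O=C1O/C(=C\Cn2cc(-c3cc(F)cc(F)c3)nn2)C(OCc2ccccc2)=C1OCc1ccccc1` differs from it in one place: 3,5-difluorophenyl in place of 4-methoxyphenyl on an aromatic carbon. Going by the values given here, the only measured step, a 2.2-fold lower number from compound 1 to compound 3 (0.33 log units; beyond the scatter), concerns a different position and a different kind of group, so it does not bear on this change. Among the compounds with values here, with no step of the same kind to lean on, compound 4 is expected to stay near the limit, with an at least 1.1-fold lower number from compound 2 to compound 4 (0.04 log units; that floor lies within the scatter) as the expected step. Compound 4 is therefore estimated at 90000 nM, between 30000 nM and 300000 nM.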

Compound 4, half-maximal inhibitory concentration: > 100000 nM
Compound 4 gave a limit, no number; the forecaster's own chance of this, stated with the estimate: 60%; at least 1.1-fold (0.04 log units) between middle value and limit.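

Going by these compounds alone, compound 2 and compound 4 both stand at a limit in this assay, so no step between them can be read: the limit of > 100000 nM in this assay, at which 2 of the 4 values shown sit. On these data alone, how 3,5-difluorophenyl and 4-methoxyphenyl compare on the shared core stays open.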